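The source may hold more compounds than are shown below. What is called first, only, known or untested is meant among the compounds shown, and "the series" means these compounds.

Measured compounds:

Compound 1, `C/N=C(\S)NCCCCn1nc(C)ccc1=O`, gives 44.5%.
Compound 2, `O=c1ccc(-c2ccccc2)nn1CCCNC(=S)Nc1ccccc1`, gives 12.1%.
Compound 3, `N#CNC(=N)NCCCCCn1nc(-c2ccccc2)ccc1=O`, gives 31%.

All three numbers come from a functional assay on the whole organism with Rattus norvegicus as the target, at a dose of 100 mg/kg; on this read-out higher numbers stand for more inhibition at the one dose given (going by the name of the read-out) and lower numbers for less inhibition. Among them compound 3 stands second highest of three: compound 1 sits higher by a gap beyond the scatter of repeated measurements, while compound 2 sits lower, again by a gap beyond the scatter. So compound 3 occupies the middle of a spread that is genuinely wide, not just noise.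

Compound 4, `CC/N=C(\S)NCCCCCn1nc(-c2ccccc2)ccc1=O`, has not yet been measured in this assay. It differs from compound 3 in one place: a group of 5 heavy atoms (3 carbon, 1 nitrogen, 1 sulfur; no ring) in place of a group of 5 heavy atoms (2 carbon, 3 nitrogen; no ring), on an amine nitrogen. For the measured compounds named here, the group that enters resembles the sulfur-bearing group carried by compound 1, whereas the group that leaves contains the nitrile seen only in compound 3.

Going by the values given here, no measured pair in this set isolates exactly this change, so the size of the step cannot be read off directly. Because compound 1 gives 44.5% and carries the closest relative of the entering group, a moderate rise is expected; the step of a number 9 percentage points higher from compound 3 to compound 4 (within the scatter) is the estimated change, a little beyond the scatter. For compound 4 the estimated value is 40%, with a plausible range from 22% to 58%.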

Compound 4, a percentage reported as inhibition, in the whole organism at one dose (the size of the read-out at that dose, not a potency): 66.4%
Beside the measured number, compound 4's estimate is 26.4 percentage points below it; the whole stated range lies below it.
By their numbers in this assay, from the lowest: compound 2; then compound 3; then compound 1; then compound 4.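

For the compounds shown here, on this assay the exchange on an amine nitrogen gives a number 35.4 percentage points higher from compound 3 to compound 4 (beyond the scatter) and so provides the first direct reading of a change at this place. Both groups contain 5 heavy atoms and no ring, so the heavy-atom count does not separate them, yet the group of 3 carbon, 1 nitrogen and 1 sulfur and the group of 2 carbon and 3 nitrogen give clearly different results on the same core and chain. Nothing available here accounts for the size of this step.

As far as these compounds go, the two groups differ in several atoms at once, so it remains open which part of the exchange matters, and an oxygen in place of the sulfur, or a methyl or a propyl group in place of the two-carbon part of the entering group, would help to separate these parts. Compound 1 and compound 2 differ from compound 4 in more than one place, so they cannot show whether a shorter chain or a phenyl group on the entering group would keep this gain at the one dose tested.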